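Changing the Phenyl Group on a Shared Core

This account rests on a few compounds, and the source may have more. Where it says the series, first, only, none or still open, it means among the compounds named here.

Two measured compounds share a large common core and differ only in the aromatic group attached through an oxygen. Compound 1 `CC[C@@H]1/C=C(\C)C[C@H](C)C[C@H](OC)[C@H]2O[C@@](O)(C(=O)C(=O)N3CCCC[C@H]3C(=O)O[C@H](/C(C)=C/[C@@H]3CC[C@@H](Oc4cccc(C)c4)[C@H](OC)C3)[C@H](C)[C@@H](O)CC1=O)[C@H](C)C[C@@H]2OC` carries a methyl on that aromatic ring; in a functional assay on cells for inhibition, with Murine T-cell line (Mus musculus) as the target (a higher number here means a weaker inhibitor, a lower number a stronger inhibitor), compound 1 gives 5.4 nM. Compound 2 `CC[C@@H]1/C=C(\C)C[C@H](C)C[C@H](OC)[C@H]2O[C@@](O)(C(=O)C(=O)N3CCCC[C@H]3C(=O)O[C@H](/C(C)=C/[C@@H]3CC[C@@H](Oc4cccc(OC)c4)[C@H](OC)C3)[C@H](C)[C@@H](O)CC1=O)[C@H](C)C[C@@H]2OC` carries a methoxy in place of that methyl, and in this assay compound 2 gives 3.4 nM. The step of a 1.6-fold lower number from compound 1 to compound 2 (0.20 log units; within the scatter) is small. Compound 2 thus shows the lowest of the two numbers, yet its nearest neighbour, compound 1, lies within the scatter of it, so the two cannot be ranked.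

Compound 3 `CC[C@@H]1/C=C(\C)C[C@H](C)C[C@H](OC)[C@H]2O[C@@](O)(C(=O)C(=O)N3CCCC[C@H]3C(=O)O[C@H](/C(C)=C/[C@@H]3CC[C@@H](Oc4ccc(SC)cc4)[C@H](OC)C3)[C@H](C)[C@@H](O)CC1=O)[C@H](C)C[C@@H]2OC` has not yet been measured. It differs from compound 2 in this way: 4-(methylsulfanyl)phenyl in place of 3-methoxyphenyl on an oxygen on a saturated carbon. Among the compounds with values here, the only measured step, the exchange of methyl for methoxy on the aromatic ring, was within the scatter and bears only loosely on an exchange of one whole aromatic group for another. There is no firm guidance, so the expected step is a 1.2-fold higher number from compound 2 to compound 3 (0.07 log units; within the scatter), that is, no change beyond the scatter. Compound 3 is estimated to give 4 nM, with a range from 1.5 nM to 11 nM.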

Compound 3, half-maximal inhibitory concentration: 2.6 nM
For compound 3 the middle estimate is 1.5-fold (0.19 log units) above the measured one; the range from low to high includes it.
By their numbers in this assay, from the lowest: compounds 3, 2 and 1 (each within the scatter of the next, the first and the last beyond it).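

The exchange of a whole aromatic group at this oxygen on a saturated carbon, with sulfur entering the ring's substituent and oxygen leaving it, gives a 1.3-fold lower number from compound 2 to compound 3 (0.12 log units; within the scatter) in this assay, so compound 2 and compound 3 cannot be ranked and this position accepts 4-(methylsulfanyl)phenyl as readily as 3-methoxyphenyl. Set against 3-methylphenyl, the same group gives a 2.1-fold lower number from compound 1 to compound 3 (0.32 log units; beyond the scatter), which is modest but is the first step in this small set to clear the scatter, whereas compound 1 and compound 2 could not be told apart. Nothing measured here accounts for these numbers.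

Compound 2 and compound 3 differ both in the atom that links the small substituent to the ring and in where that substituent sits, so these compounds cannot show which of the two changes matters, if either does. As far as these compounds go, it also remains open how the number would respond to an amine or a carboxylic acid on the aromatic ring, or to a longer chain in place of the methylsulfanyl group.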